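The compounds below may be only part of what the source reports. "The series", "measured", "known", "first", "only" and "open" are said of these compounds alone.

Measured so far:
Compound 1 `CC(C)(C)c1cc(NC(=O)[C@@H]2CCCCN2C(=O)c2ccccc2)no1` gives 0.683 h.
Compound 2 `CC(C)(C)c1cc(NC(=O)[C@@H]2CCCCN2C(=O)C2CCOCC2)no1` gives > 2 h.
Compound 3 `CC(C)(C)c1cc(NC(=O)[C@@H]2CCCCN2C(=O)N2CCCCC2)no1` gives 0.233 h.

These three were run in an ADME assay (liver) for metabolic stability, with Liver microsome (Homo sapiens) as the target, read by LC-MS, using microsomes and NADPH, tested at 1 uM; a lower number here means that the compound disappears faster, a higher number that the compound lasts longer. Among the two numbers that are not limits, compound 3 stands lowest; the move from compound 1 to compound 3 shows a 2.9-fold lower number from compound 1 to compound 3 (0.47 log units; beyond the scatter), so the gap is beyond the usual scatter. The value of compound 2 is a limit of the assay, not a number, as the limit of > 2 h in this assay, at which 1 of the 3 values shown sits, states.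

Compound 4 `CC(=O)N1CCN(C(=O)N2CCCC[C@H]2C(=O)Nc2cc(C(C)(C)C)on2)CC1` differs from compound 3 in one place: 4-acetylpiperazin-1-yl in place of piperidin-1-yl on a carbonyl carbon. The two measured steps that end at compound 3 both change the same carbonyl carbon. Replacing phenyl there gave a 2.9-fold lower number from compound 1 to compound 3 (0.47 log units; beyond the scatter), and replacing oxan-4-yl gave an at least 8.5-fold lower number from compound 2 to compound 3 (0.93 log units; beyond the scatter). Changes at this position have therefore moved the half-life by modest or larger amounts in both directions, and compound 3 now carries the group that each of those steps introduced. The change to compound 4 is expected to bring a modest rise in this assay, a 2.1-fold higher number from compound 3 to compound 4 (0.33 log units; beyond the scatter), though the direction is not firmly settled by the two measured steps. The estimate for compound 4 is 0.5 h, with a plausible range from 0.2 h to 1.5 h.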

Compound 4, half-life: > 2 h
Compound 4: no number, only a limit; the forecaster's own chance of this, stated with the estimate: 10%; middle value at least 4.0-fold (0.60 log units) from the limit.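

Compound 3 had suggested that a ring joined through its nitrogen to this carbonyl carbon shortens the half-life, but compound 4 is joined the same way and behaves very differently: the change to 4-acetylpiperazin-1-yl gives an at least 8.5-fold higher number from compound 3 to compound 4 (0.93 log units; beyond the scatter) in this assay and so undoes the low reading of compound 3. The same group also compares well with the aromatic ring, with an at least 2.9-fold higher number from compound 1 to compound 4 (0.46 log units; beyond the scatter) showing that a nitrogen-linked ring at this position need not fall behind phenyl. The half-life of compound 4 is a limit of the assay, not an exact number, and compound 2 also sits at that limit: the limit of > 2 h in this assay, at which 2 of the 4 values shown sit.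

From the compounds shown here alone, the step between compound 2 and compound 4 cannot be read, so the order of oxan-4-yl and 4-acetylpiperazin-1-yl remains unknown. The compounds shown also cannot say which part of the new group goes with the rise, and a piperazine bearing a free amine, or one with a propanoyl chain in place of the acetyl, would be needed to separate the ring from its acetyl.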